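This account rests on a few compounds, and the source may have more. Where it says the series, first, only, none or still open, it means among the compounds named here.

Measured compounds:
compound 1, `Oc1nc(SCCCCCCCCc2ccccc2)ncc1Cc1ccccn1`: 38%
compound 2, `Oc1nc(SCCCCCCCCc2ccccc2)ncc1Cc1ccccc1`: 0%

In an assay on isolated protein for inhibition of platelet-activating factor acetylhydrolase (Homo sapiens), tested at 10 uM (on this read-out lower numbers stand for less inhibition and higher numbers for more inhibition at the one concentration tested (going by the name of the read-out)), compound 1 gives 38%, and compound 2 gives 0%. Among the compounds with values here, compound 2 thus stands as the lower of the two numbers in this assay; its only neighbour is compound 1, and the step of a number 38 percentage points lower from compound 1 to compound 2 (beyond the scatter) is beyond the scatter.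

Compound 3, `Oc1nc(SCCCCCCCCc2ccccc2)ncc1Cc1ccoc1`, has not been measured. Its change from compound 2 is furan-3-yl in place of phenyl on a saturated chain carbon bound to an aromatic carbon. Within the data shown here, the one step that bears on it, a number 38 percentage points lower from compound 1 to compound 2 (beyond the scatter), swapped a six-membered ring with one hetero atom for phenyl and cost a great deal; compound 3 reverses the direction of that kind of swap, but with a five-membered ring bearing one hetero atom, which no measured pair covers. A modest rise is therefore expected, likely within the scatter, as the step of a number 12 percentage points higher from compound 2 to compound 3 (beyond the scatter). The estimate for compound 3 is 12%, ranging from 0% to 30%.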

Compound 3, a percentage reported as inhibition, at one concentration (the size of the read-out at that concentration, not a potency): 63%
The estimate for compound 3 lay 51 percentage points below the measured number; the whole stated range lies below it.
By their numbers in this assay, from the lowest: compound 2; then compound 1; then compound 3.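

In this assay, the step of a number 63 percentage points higher from compound 2 to compound 3 (beyond the scatter) shows that on a saturated chain carbon bound to an aromatic carbon, a five-membered furan-3-yl ring can take the place of phenyl with a large gain. The step of a number 25 percentage points higher from compound 1 to compound 3 (beyond the scatter) adds that the two rings bearing a hetero atom are not equivalent here, so the presence of a hetero atom alone does not set the number at this position. Nothing measured on these groups accounts for this order.

From the compounds shown here alone, whether furan-2-yl, thiophen-3-yl or the saturated tetrahydrofuran-3-yl would match furan-3-yl stays open, as does whether its gain persists with a shorter chain in place of the one ending in phenyl. Going by these compounds, each number also comes from a single concentration, so the relative potencies of the compounds remain unknown.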